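Rearranging a fused bicycle: expected solubility of compound 4

This account rests on a few compounds, and the source may have more. Where it says the series, first, only, none or still open, it means among the compounds named here.

Compound 3 `CC(=O)N[C@@H]1CCC[C@H](C(=O)Nc2cc(-c3cnn4c3CCCCC4)c(Cl)cn2)C1` stands second highest of the three measured numbers in a physicochemical assay for solubility, in phosphate buffer, at pH 7.4 (on this read-out lower numbers stand for lower solubility and higher numbers for higher solubility), giving 104000 nM. Compound 1 `CC(=O)N[C@@H]1CCC[C@H](C(=O)Nc2cc(-c3cnn(C)c3C)c(Cl)cn2)C1` gives 960000 nM, and compound 2 `CC(=O)N[C@@H]1CCC[C@H](C(=O)Nc2cc(-c3cnn4ccccc34)c(Cl)cn2)C1` gives 45000 nM. The measured steps run a 21-fold lower number from compound 1 to compound 2 (1.33 log units; beyond the scatter), a 9.2-fold lower number from compound 1 to compound 3 (0.97 log units; beyond the scatter) and a 2.3-fold higher number from compound 2 to compound 3 (0.36 log units; beyond the scatter). Compound 4 `CC(=O)N[C@@H]1CCC[C@H](C(=O)Nc2cc(-c3cnc4n3CC(C)(C)C4)c(Cl)cn2)C1` holds the same atoms as compound 3 joined differently: a group of 10 heavy atoms (8 carbon, 2 nitrogen; one five-membered non-aromatic ring with 1 hetero atom, one five-membered aromatic ring with 2 hetero atoms) in place of a group of 10 heavy atoms (8 carbon, 2 nitrogen; one five-membered aromatic ring with 2 hetero atoms, one seven-membered non-aromatic ring with 1 hetero atom), on an aromatic carbon. Within the data shown here, no measured step exchanges one fused bicycle for another of identical composition; both steps from compound 1 lower the number, and the step from compound 2 to compound 3 is only modest. Compound 4 is therefore expected to give 80000 nM, within 30000 nM to 200000 nM, an expected step of a 1.3-fold lower number from compound 3 to compound 4 (0.11 log units; within the scatter) that stays at most modest.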

Compound 4, solubility: 280000 nM
The estimate for compound 4 lay 3.5-fold (0.54 log units) below the measured number, outside the stated range (above it).
By their numbers in this assay, from the lowest: compound 2; then compound 3; then compound 4; then compound 1.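

In this assay, the place on an aromatic carbon opposite the ring nitrogen proves sensitive to how the same atoms are joined, with a 2.7-fold higher number from compound 3 to compound 4 (0.43 log units; beyond the scatter). The fused group of compound 4 also reads well clear of the aromatic bicycle, with a 6.2-fold higher number from compound 2 to compound 4 (0.79 log units; beyond the scatter), yet does not reach the smaller group, with a 3.4-fold lower number from compound 1 to compound 4 (0.54 log units; beyond the scatter). No measurement shown here explains these differences. Still open, on these data alone, is how an amine or a carboxylic acid on the fused group would read in this assay.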